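The source may hold more compounds than are shown below. What is called first, only, known or untested is meant among the compounds shown, and "the series" means these compounds.

Working notes on the alpha-galactosidase series.

Compound 1 `COc1ccc([C@]2(CO)NC[C@@H](O)[C@@H]2O)cc1` carries a methoxy group on its aromatic ring. In an assay on isolated protein for inhibition of alpha-galactosidase (Coffea arabica), tested at 1000 uM (on this read-out lower numbers stand for less inhibition and higher numbers for more inhibition at the one concentration tested (going by the name of the read-out)), compound 1 gives 7.5%. Two further compounds with the same core have been measured. Compound 2 `CCCCCCCCC[C@]1(CO)NC[C@@H](O)[C@@H]1O` gives 2.5% in this assay, and compound 3 `OC[C@@]1(c2c(F)c(F)c(F)c(F)c2F)NC[C@@H](O)[C@@H]1O` gives 0%. All three numbers lie within the usual scatter of one another, so nothing separates compound 1 from compound 2 or compound 3 on this read-out; the whole set sits close to the floor of the assay.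

Compound 4 `OC[C@@]1(c2ccccc2)NC[C@@H](O)[C@@H]1O` has not yet been measured in this assay. Compared with compound 1 the change is hydrogen in place of methoxy on an aromatic carbon. Among the compounds with values here, no measured pair in the set isolates this change, so its effect is not known from the data. Given that compound 1 gives 7.5% and that the whole set reads low, compound 4 is expected to stay close to the others, with a step from compound 1 to compound 4 of a number 2.5 percentage points lower from compound 1 to compound 4 (within the scatter), not beyond the scatter. The estimate for compound 4 is 5%, in the range 0% to 15%.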

Compound 4, a percentage reported as inhibition, at one concentration (the size of the read-out at that concentration, not a potency): 9.9%
Estimate against measurement, compound 4: 4.9 percentage points below, within the range that was stated.
By their numbers in this assay, from the lowest: compounds 3, 2, 1 and 4 (each within the scatter of the next).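

Within the data shown here, the step of a number 2.4 percentage points higher from compound 1 to compound 4 (within the scatter), for hydrogen in place of methoxy on an aromatic carbon para to a group of 9 heavy atoms, is the first comparison that isolates a single change. In this assay, this pair therefore shows no effect of the methoxy group at this position that can be told apart from the scatter. Nothing available explains the result.

Going by these compounds, it remains open whether an amine or a carboxylic acid at this aromatic carbon would give a reading beyond the scatter from compound 4 in this assay. Also open, on these data alone, is whether any replacement at this position would lift the shared core clear of the floor of the assay.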